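Swapping a Hydroxymethyl Arm for a Plain Branched Chain

The source may hold more compounds than are shown below. What is called first, only, known or untested is meant among the compounds shown, and "the series" means these compounds.

Compound 3 `CCC[C@H](CO)Nc1nc(C)nc2c1c(C)nn2-c1ccc(OC)cc1C` has the lowest number of the three compounds in a functional assay on CHO cells for antagonist activity at corticotropin-releasing factor receptor 1 (Homo sapiens), read by cAMP accumulation (on this read-out lower numbers stand for stronger inhibition and higher numbers for weaker inhibition), where compound 3 gives 76 nM. Compound 2 `CCCNCc1nc(Nc2nc(C)nc3c2c(C)nn3-c2ccc(OC)cc2C)no1` gives 124 nM, and compound 1 `CCCN(CC(=O)N(C)C)c1nc(C)nc2c1c(C)nn2-c1ccc(OC)cc1C` gives 1410 nM. Compound 4 `CCC(CC)Nc1nc(C)nc2c1c(C)nn2-c1ccc(OC)cc1C` differs from compound 3 by pentan-3-yl in place of 1-(hydroxymethyl)butyl on a nitrogen on an aromatic ring. Within the data shown here, two measured steps concern this same nitrogen: a 19-fold lower number from compound 1 to compound 3 (1.27 log units; beyond the scatter) and a 1.6-fold lower number from compound 2 to compound 3 (0.21 log units; within the scatter). Among the measured compounds shown here, the first shows that the group on this nitrogen can shift the number strongly; the second shows that two quite different groups can land close together. Neither step removes the hydroxymethyl part alone, so the direction is uncertain. The step is therefore expected to be modest, a 1.4-fold higher number from compound 3 to compound 4 (0.16 log units; within the scatter), in this assay. Compound 4 is estimated at 110 nM, with a range from 30 nM to 400 nM.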

Compound 4, inhibition constant: 42 nM
For compound 4 the middle estimate is 2.6-fold (0.42 log units) above the measured one, and the stated range covers the measured number.
By their numbers in this assay, from the lowest: compounds 4, 3 and 2 (each within the scatter of the next, the first and the last beyond it); then compound 1.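

In this assay, the step with pentan-3-yl in place of 1-(hydroxymethyl)butyl, a 1.8-fold lower number from compound 3 to compound 4 (0.26 log units; within the scatter), stays within the scatter, so the hydroxymethyl part and its defined stereocentre are not required for a number in this range. The plain branched chain also gives a 3.0-fold lower number from compound 2 to compound 4 (0.47 log units; beyond the scatter) and a 34-fold lower number from compound 1 to compound 4 (1.53 log units; beyond the scatter), the first modest and the second large. Nothing measured here explains these steps.

Going by these compounds, whether a longer chain such as heptan-4-yl or a ring such as cyclopentyl on this nitrogen would go lower remains open. So does the effect of an amine or carboxylic acid on the chain.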